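Ester to enone replacement in the anilide series

The source may report more compounds than this note shows. Statements on the series, on what has been measured and on what is new or still open speak of the compounds shown alone.

Compound 1 `COc1ccc(NC(=O)CSC(=S)N[C@H]2CCOC2=O)cc1` carries a methoxy on the aromatic ring. In a functional assay on MCF7 cells (Homo sapiens) for cytotoxicity, read by MTT assay, with a stated time of 72 h (a higher number here means a weaker inhibitor, a lower number a stronger inhibitor), compound 1 gives only a limit, > 128000 nM, as noted in the limit of > 128000 nM in this assay, at which 1 of the 3 values shown sits. Compound 2 `O=C(CSC(=S)N[C@H]1CCOC1=O)Nc1ccc(F)cc1` has fluoro in place of that methoxy, and in this assay compound 2 gives 5830 nM. Compound 3 `CCOC(=O)c1ccc(NC(=O)CSC(=S)N[C@H]2CCOC2=O)cc1` carries ethoxycarbonyl in place of the methoxy, and in this assay compound 3 gives 60300 nM. Of the two plain numbers, compound 3 holds the higher one: the step of a 10-fold higher number from compound 2 to compound 3 (1.01 log units; beyond the scatter) is large. The steps of an at least 21-fold lower number from compound 1 to compound 2 (1.34 log units; beyond the scatter) and an at least 2.1-fold lower number from compound 1 to compound 3 (0.32 log units; beyond the scatter) start from a limit and set lower bounds only.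

Compound 4 `O=C(CSC(=S)N[C@H]1CCOC1=O)Nc1ccc(C(=O)/C=C/c2ccccc2Cl)cc1` differs from compound 3 by 2-(2-chlorophenyl)ethenyl in place of ethoxy on a carbonyl carbon. Among the measured compounds shown here, every measured step in this set swaps the substituent on the aromatic carbon; none touches the carbonyl carbon that is changed here, so no step bears directly on this change. The spread among the measured compounds runs from a limit down to the value of compound 2, and a change of this size may move the number in either direction. For compound 4 a step of a 3.0-fold lower number from compound 3 to compound 4 (0.48 log units; beyond the scatter) is expected, a modest lowering with wide uncertainty. Compound 4 is estimated at 20000 nM in this assay, with a range from 4000 nM to 100000 nM.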

Compound 4, half-maximal inhibitory concentration: 5570 nM
For compound 4 the middle estimate is 3.6-fold (0.56 log units) above the measured one; the measured number falls inside the stated range.
By their numbers in this assay, from the lowest: compounds 4 and 2 (each within the scatter of the next); then compound 3. At a limit, above all of these: compound 1.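

Among the compounds shown here, replacing ethoxy with 2-(2-chlorophenyl)ethenyl on the carbonyl carbon gives an 11-fold lower number from compound 3 to compound 4 (1.03 log units; beyond the scatter) in this assay, so the substituent on that carbonyl carbon, which no earlier step touched, also moves the number. The result also places two very different substituents on the aromatic carbon at one level: the fluoro of compound 2 and the carbonyl-linked 2-(2-chlorophenyl)ethenyl of compound 4 lie within the scatter of each other, so a much larger group on that carbon does not by itself weaken the number here. No measurement shown accounts for the size of this step.

The compounds shown do not separate what the double bond, the aromatic ring and the chlorine each contribute to the step; a plain 2-phenylethenyl and a saturated 2-(2-chlorophenyl)ethyl on the same carbonyl carbon would pull these parts apart. Also open, from the compounds shown here alone, is how the carbonyl carbon responds to other replacements for ethoxy, such as a hydroxyl that makes a carboxylic acid, or an amine that makes an amide.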